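The source may report more compounds than this note shows. Statements on the series, on what has been measured and on what is new or still open speak of the compounds shown alone.

Within the data shown here, in a functional assay on MCF7 cells (Homo sapiens) for cytotoxicity, read by MTT assay, with a stated time of 72 h (a lower number here means a stronger inhibitor, a higher number a weaker inhibitor), the compounds measured so far all sit at the weak end. Compound 1 `Cc1ccc(-c2ccc(C(=O)Nc3ccc(Oc4ccnc5[nH]ccc45)cc3)nc2)cc1` gives > 10000 nM, which is a limit of the assay rather than a number (the limit of > 10000 nM in this assay, at which 1 of the 3 values shown sits). Compound 2 `O=C(Nc1ccc(Oc2ccnc3[nH]ccc23)cc1)c1cc(-c2ccccc2)ccn1` gives 3750 nM, while compound 3 `Cc1cccc(-c2ccnc(C(=O)Nc3ccc(Oc4ccnc5[nH]ccc45)c(F)c3)c2)c1` gives 9120 nM, the higher of the two numbers, and that gap lies beyond the scatter. Compound 4 `O=C(Nc1ccc(Oc2ccnc3[nH]ccc23)c(F)c1)c1cc(-c2ccc(F)cc2F)ccn1` differs from compound 3 in one place: 2,4-difluorophenyl in place of 3-methylphenyl on an aromatic carbon. Among the measured compounds shown here, no measured pair shows such a swap, so the expectation rests on compound 3 alone, and the step is expected to be small, most likely within the scatter, with only a slight lean toward a lower number. Compound 4 is therefore estimated at 7000 nM, between 2500 nM and 20000 nM, which would mean a step of a 1.3-fold lower number from compound 3 to compound 4 (0.11 log units; within the scatter).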

Compound 4, half-maximal inhibitory concentration: > 10000 nM
Compound 4 ended at the assay's limit; the forecaster's own chance of this, stated with the estimate: 25%; middle value at least 1.4-fold (0.15 log units) away from the limit.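

In this assay, 2,4-difluorophenyl in place of 3-methylphenyl on this aromatic carbon, opposite the ring nitrogen, gives an at least 1.0-fold higher number from compound 3 to compound 4 (0.04 log units; that floor lies within the scatter). Compound 4 gives a limit of the assay, not a number, so this step has a floor but no known size, and the change shows no gain in strength. The weak end of the series now holds one more compound: the limit of > 10000 nM in this assay, at which 2 of the 4 values shown sit.

Still open, as far as these compounds go, is whether any group at this carbon gives a clearly lower number. A phenyl ring carrying an amine or a carboxylic acid, or a simple amine in place of the ring, could test this.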